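The source may report more compounds than this note shows. Statements on the series, on what has been measured and on what is new or still open speak of the compounds shown alone.

Compound 1 `COc1ccc(N(C)c2nc(C)nc3ccccc23)cc1OCCCCC[Se]C#N`: 2440 nM
Compound 2 `COc1ccc(N(C)c2nc(C)nc3ccccc23)cc1C(=O)OCCCCCC[Se]C#N`: 488 nM

Of the compounds shown here, two on a shared core have been measured in a functional assay on A549 cells (Homo sapiens) for inhibition, read by MTT assay, with a stated time of 48 h; on this read-out lower numbers stand for stronger inhibition and higher numbers for weaker inhibition. Compound 1 gives 2440 nM, the higher of the two numbers; compound 2 gives 488 nM, a lower number that lies beyond the usual scatter of the measurement. Among the measured compounds shown here, no single-change step connects these two compounds, so their gap says only what the two values show.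

Compound 3 `COc1ccc(N(C)c2nc(C)nc3ccccc23)cc1OCCCC[Se]C#N` has not yet been measured in this assay. It differs from compound 1 in one place: a group of 3 heavy atoms (1 carbon, 1 nitrogen, 1 selenium; no ring) in place of a group of 4 heavy atoms (2 carbon, 1 nitrogen, 1 selenium; no ring), on a saturated chain carbon, four bonds along the chain from an oxygen on an aromatic ring. The chain that carries the selenium end is thus shorter at the same place, with the triple bond and the acceptor unchanged. For the measured compounds named here, no measured pair here covers such a shortening, so the step from compound 1 to compound 3 is expected to be small, a 1.0-fold higher number from compound 1 to compound 3 (0.01 log units; within the scatter), not beyond the scatter in either direction. The expected value for compound 3 is therefore 2500 nM, with a range from 1200 nM to 5500 nM.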

Compound 3, half-maximal inhibitory concentration: 1200 nM
Compound 3: the middle estimate sits 2.1-fold (0.32 log units) above what was measured; low and high end bracket the measured number.
By their numbers in this assay, from the lowest: compound 2; then compound 3; then compound 1.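

In this assay, the change at this position, a group of 3 heavy atoms (1 carbon, 1 nitrogen, 1 selenium; no ring) in place of a group of 4 heavy atoms (2 carbon, 1 nitrogen, 1 selenium; no ring), on a saturated chain carbon, four bonds along the chain from an oxygen on an aromatic ring, gives a 2.0-fold lower number from compound 1 to compound 3 (0.31 log units; beyond the scatter) on this read-out. Among the compounds shown here, this is the first single-change step, and it shows that the read-out responds to the length of this chain, modestly but beyond the usual scatter. Nothing measured here bears on the reason for this step.

As far as these compounds go, a single step gives a direction for one pair only, so it remains open whether a still shorter chain would continue it. From the compounds shown here alone, how sulfur in place of selenium, or an amine at the chain end, would read on this chain also remains open.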